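Adding a Third Methoxy Group: From Compound 3 to Compound 4

This account rests on a few compounds, and the source may have more. Where it says the series, first, only, none or still open, it means among the compounds named here.

Compound 1 `CCOc1cccc2cc(-c3ccc(Br)cc3)c(=O)oc12` gives in a functional assay on CHO cells for antagonist activity at adenosine receptor A2b (Homo sapiens), read by cAMP accumulation (a higher number here means a weaker inhibitor, a lower number a stronger inhibitor), only a limit of the assay, > 30000 nM.
Compound 2 `CCOc1cccc2cc(-c3ccc(OC)cc3)c(=O)oc12` gives in this assay only a limit, > 30000 nM.
Compound 3 `CCOc1cccc2cc(-c3ccc(OC)c(OC)c3)c(=O)oc12` gives in this assay only a limit, > 30000 nM.

Compound 3 therefore stands at the edge of what this assay can report, and every measured value in the set rests at the same edge, as the limit of > 30000 nM in this assay, at which 3 of the 3 values shown sit, records. The two measured steps, a step that the two limits leave unreadable from compound 1 to compound 2 and a step that the two limits leave unreadable from compound 2 to compound 3, cannot be sized, since both ends of each sit at a limit. Compound 4 `CCOc1cccc2cc(-c3cc(OC)c(OC)c(OC)c3)c(=O)oc12` differs from compound 3 by methoxy in place of hydrogen on an aromatic carbon. The step from compound 2 to compound 3 is the closest model, being the same kind of change, yet it gives no readable size or direction. Among the compounds with values here, with no measured step to build on, compound 4 is expected to remain at the limit, so that a step that the limit leaves unreadable from compound 3 to compound 4 is an expected step of no readable size. The estimated value for compound 4 in this assay is 40000 nM, within an expected range from 10000 nM to 150000 nM.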

Compound 4, half-maximal inhibitory concentration: > 30000 nM
Compound 4 gave a limit, no number; the forecaster's own chance of this, stated with the estimate: 85%; the middle value lies beyond the limit too.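

Within the data shown here, compound 3 and compound 4 both give a limit of the assay rather than a number, so no step between them can be read, in size or in direction: the limit of > 30000 nM in this assay, at which 4 of the 4 values shown sit.
The compounds shown leave open whether any of these group changes alters inhibition in this assay at all.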